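The source may report more compounds than this note shows. Statements on the series, on what has been measured and on what is new or still open speak of the compounds shown alone.

Measured in a functional assay on Rec1 cells (Homo sapiens) for inhibition, read by luminescence and CellTiter-Glo, with a stated time of 72 h; a lower number here means a stronger inhibitor, a higher number a weaker inhibitor:
- compound 1 `C/C=C/C(=O)Nc1cccc(Cn2nc(-c3ccc(Oc4ccccc4)cc3)cc2C(=O)O)c1`: 26000 nM
- compound 2 `C/C=C/C(=O)Nc1cccc(Cn2nc(-c3ccc(Oc4ccccc4)cc3)cc2C(=O)OCC)c1`: 7800 nM

Not yet measured: compound 3 `C=CC(=O)Nc1cccc(Cn2nc(-c3ccc(Oc4ccccc4)cc3)cc2C(=O)O)c1`.

Of the two measured compounds, compound 1 has the higher number. Within the data shown here, the only measured step is a 3.3-fold lower number from compound 1 to compound 2 (0.52 log units; beyond the scatter). The next change leads to compound 3: vinyl in place of prop-1-en-1-yl on a carbonyl carbon. The measured step does not touch this group, so it bears only indirectly, as a gauge of how far one change has moved this assay in this small series. Among the measured compounds shown here, no measurement yet covers the change itself. With compound 1 at 26000 nM, the higher of the two numbers, a modest move toward a lower number is expected, though this direction is tentative. The expected step is a 2.0-fold lower number from compound 1 to compound 3 (0.30 log units; within the scatter). For compound 3 the estimated value is 13000 nM, with an expected range of 4000 nM to 35000 nM.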

Compound 3, half-maximal inhibitory concentration: 33100 nM
Beside the measured number, compound 3's estimate is 2.5-fold (0.41 log units) below it, and the stated range covers the measured number.
By their numbers in this assay, from the lowest: compound 2; then compounds 1 and 3 (each within the scatter of the next).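

In this assay the swap of prop-1-en-1-yl for vinyl on the carbonyl carbon gives a 1.3-fold higher number from compound 1 to compound 3 (0.10 log units; within the scatter) and so lies within the scatter; on the carboxylic acid form of the core, the two compounds cannot be told apart. Among these compounds, this is the first reading at this position, and the only step beyond the scatter so far is a 3.3-fold lower number from compound 1 to compound 2 (0.52 log units; beyond the scatter) at a different place in the molecule. No measured evidence at hand bears on the reason for this result.

Whether the same swap reads alike on the ethyl ester of compound 2 remains open, since the compounds shown carry it only on the carboxylic acid. Also open, from the compounds shown here alone, is how a longer chain or an amine-bearing chain on the same carbonyl carbon would read.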